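Swapping the aryl ketone end of a quinoline chalcone

The source may hold more compounds than are shown below. What is called first, only, known or untested is meant among the compounds shown, and "the series" means these compounds.

Measured so far:
- compound 1, `COc1ccc(-c2cc3ccccc3nc2C=O)cc1`: > 10000 nM
- compound 2, `COc1ccc(-c2cc3ccccc3nc2/C=C/C(=O)c2ccc(OC)cc2OC)cc1`: 7990 nM

In a functional assay on A549 cells (Homo sapiens) for antiproliferative activity, read by XTT assay, with a stated time of 72 h (on this read-out lower numbers stand for stronger inhibition and higher numbers for weaker inhibition), compound 1 reaches only the limit of the assay, > 10000 nM, which is not a number. Compound 2, which carries the extended chalcone arm, gives 7990 nM in this assay. Among the two results shown, compound 2 therefore stands as the only real number; the other result is a limit, and the gap between them cannot be sized as a step.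

Compound 3, `COc1ccc(-c2cc3ccccc3nc2/C=C/C(=O)c2cccs2)cc1`, keeps the whole of compound 2 apart from one change: thiophen-2-yl in place of 2,4-dimethoxyphenyl on a carbonyl carbon.

For the measured compounds named here, no step between measured compounds has been counted here, so the direction of this change rests on no measured precedent. The step from compound 2 to compound 3 is expected to stay within the scatter of this assay, or to drift only slightly toward weaker inhibition, a 1.1-fold higher number from compound 2 to compound 3 (0.05 log units; within the scatter). Compound 3 is therefore expected to land near 9000 nM in this assay, within a range of 3000 nM to 30000 nM, with a real chance that the assay again reports only its limit.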

Compound 3, half-maximal inhibitory concentration: 920 nM
Estimate against measurement, compound 3: 9.8-fold (0.99 log units) above; the whole stated range lies above it.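

In this assay, for the compounds shown here, the group on the carbonyl carbon proves to matter, something the earlier compounds could not show: an 8.7-fold lower number from compound 2 to compound 3 (0.94 log units; beyond the scatter), so replacing 2,4-dimethoxyphenyl with thiophen-2-yl moves the result well past ordinary repeat-to-repeat variation. Compound 1 has formyl where compound 3 has the 2-((thiophen-2-yl)carbonyl)ethenyl group, and compound 1 gives > 10000 nM, which is a limit of the assay and not a number. Replacing formyl with that longer group gives an at least 10-fold lower number from compound 1 to compound 3 (1.03 log units; beyond the scatter), but one end of this step is a limit, so its true size stays unknown: the limit of > 10000 nM in this assay, at which 1 of the 3 values shown sits.

The compounds shown cannot tell whether the stronger result comes from adding thiophen-2-yl or from removing 2,4-dimethoxyphenyl, since these are the only two groups compared on this carbonyl carbon, and they offer no explanation for the step. A plain phenyl ring or a furan-2-yl ring at the same place would help separate those two readings, but nothing here indicates how either would behave.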